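Benzoyl to vinyl on the sulfur side chain

The compounds below may be only part of what the source reports. "The series", "measured", "known", "first", "only" and "open" are said of these compounds alone.

Values in a functional assay on PC-9 cells (Homo sapiens) for inhibition, read by MTT assay, with a stated time of 72 h (a higher number here means a weaker inhibitor, a lower number a stronger inhibitor), are as follows.
compound 1 `Cc1cc(Nc2cc(-c3ccccc3)[nH]n2)n2nc(SCCc3ccccc3)nc2n1` gives 4930 nM
compound 2 `Cc1cc(Nc2cc(-c3ccccc3)[nH]n2)n2nc(SCc3ccc(Br)cc3)nc2n1` gives 4760 nM
compound 3 `Cc1cc(Nc2cc(-c3ccccc3)[nH]n2)n2nc(SCC(=O)c3ccccc3)nc2n1` gives 4450 nM

Compound 3 stands level with the other two, within the scatter of both. Compound 4 `C=CCSc1nc2nc(C)cc(Nc3cc(-c4ccccc4)[nH]n3)n2n1` carries vinyl in place of benzoyl on a saturated chain carbon bound to a sulfur. The measured steps bearing on this are all small (a 1.0-fold lower number from compound 1 to compound 2 (0.02 log units; within the scatter)) and (a 1.1-fold lower number from compound 1 to compound 3 (0.04 log units; within the scatter)) and (a 1.1-fold lower number from compound 2 to compound 3 (0.03 log units; within the scatter)). Each swaps one ring-bearing group for another, so none shows what removing the six-membered aromatic ring does. No step beyond the scatter is therefore expected in this assay and no direction is favoured, with wide uncertainty. The expected step is small (a 1.2-fold higher number from compound 3 to compound 4 (0.09 log units; within the scatter)). Compound 4 is estimated at 5500 nM (expected range 2500 nM to 12000 nM).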

Compound 4, half-maximal inhibitory concentration: > 50000 nM
Compound 4 gave a limit, no number; the forecaster's own chance of this, stated with the estimate: 10%; middle value at least 9.0-fold (0.95 log units) away from the limit.
By their numbers in this assay, from the lowest: compounds 3, 2 and 1 (each within the scatter of the next). At a limit, above all of these: compound 4.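

The position is not indifferent: exchanging one ring-bearing group for another left this assay unmoved, but losing the six-membered aromatic ring did not. Vinyl is a large step down in activity against benzoyl (an at least 11-fold higher number from compound 3 to compound 4 (1.05 log units; beyond the scatter)) and against 4-bromophenyl (an at least 10-fold higher number from compound 2 to compound 4 (1.02 log units; beyond the scatter)), and at least a modest one against benzyl (an at least 10-fold higher number from compound 1 to compound 4 (1.00 log units; beyond the scatter)). Compound 4 gives a limit, not a number (> 50000 nM).

The aromatic ring and the overall size of the group change together here, so the two cannot be separated. As far as these compounds go, a longer chain without a ring, such as hexyl, would separate them, and an amine on the chain remains untested ground in these compounds.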